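A few compounds are considered here, and "the series" means these few. Any claim that something is new, unique, unknown or untested is made for them only; others in the source may bear on it.

Working notes, series measured in an assay on cells for displacement of a labelled ligand from transmembrane domain-containing protein TMIGD3 (Homo sapiens), read by scintillation counting, with a stated time of 120 min, tested at 1 uM; on this read-out higher numbers stand for more inhibition at the one concentration tested (going by the name of the read-out) and lower numbers for less inhibition:

- compound 1 `Nc1nccn2cc(-c3ccccc3)nc12` gives 12%
- compound 2 `COc1ccc(-c2cn3ccnc(N)c3n2)cc1` gives 1%
- compound 3 `O=C(Nc1nccn2cc(-c3ccccc3)nc12)c1cccnc1` gives 42%

Compound 1 stands second highest of the three numbers. The two changes made from it run in opposite directions: the methoxy gives a number 11 percentage points lower from compound 1 to compound 2 (beyond the scatter), the acyl group on the amino nitrogen gives a number 30 percentage points higher from compound 1 to compound 3 (beyond the scatter).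

Compound 4 `COc1cccc(-c2cn3cc(-c4ccccc4)nc3c(N)n2)c1` differs from compound 1 by 3-methoxyphenyl in place of hydrogen on an aromatic carbon. Within the data shown here, no measured step touches that carbon of the shared core; the only step on an aromatic carbon, a number 11 percentage points lower from compound 1 to compound 2 (beyond the scatter), concerns a methoxy on the phenyl and was modest and downward. Among the measured compounds shown here, with no direct precedent, the expected step is small and of uncertain sign, estimated as a number 3 percentage points higher from compound 1 to compound 4 (within the scatter). Compound 4 is therefore estimated at 15%, with a range from 0% to 40%.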

Compound 4, a percentage reported as inhibition, at one concentration (the size of the read-out at that concentration, not a potency): 21%
The estimate for compound 4 lay 6 percentage points below the measured number, and the stated range covers the measured number.
By their numbers in this assay, from the lowest: compound 2; then compounds 1 and 4 (each within the scatter of the next); then compound 3.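

Among these compounds, this is the first reading at the aromatic carbon next to the ring nitrogen and meta to an amino group of the shared core: with 3-methoxyphenyl in place of hydrogen, a number 9 percentage points higher from compound 1 to compound 4 (within the scatter). Here a group of 8 heavy atoms leaves the number within the scatter of compound 1, whereas the earlier steps on the phenyl and on the amino nitrogen lie beyond it. Nothing available explains this reading.

Still open, as far as these compounds go, is whether a methyl, an amine or a carboxylic acid on this carbon reads the same. Also open, from the compounds shown here alone, is whether 3-methoxyphenyl here combines with (pyridin-3-yl)carbonyl on the amino nitrogen.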